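Swapping a nitrile for two chlorines on the sulfonyl ring

The compounds below may be only part of what the source reports. "The series", "measured", "known", "first", "only" and "open" are said of these compounds alone.

Measured compounds:
compound 1, `COc1ccc(NS(=O)(=O)c2cccc(C#N)c2)cc1N1CCN(C)CC1`, 63.1 nM
compound 2, `COc1ccc(NS(=O)(=O)c2c(F)c(Br)cc(F)c2Br)cc1N1CCN(C)CC1`, 3.16 nM
compound 3, `COc1ccc(NS(=O)(=O)c2ccc3c(Cl)cccc3c2)cc1N1CCN(C)CC1`, 0.794 nM

All three share one core and differ only in the aromatic ring attached to the sulfonyl sulfur. In an assay on HeLa cells for binding affinity to 5-hydroxytryptamine receptor 6 (Homo sapiens) (a lower number here means a stronger inhibitor, a higher number a weaker inhibitor), compound 1 gives the highest number of the three, so it is the weakest inhibitor shown. The nearest value is that of compound 2, which is far lower, and the lowest of all is that of compound 3; both gaps lie well beyond the usual scatter. What the values show is that the two rings carrying halogens sit far below the ring carrying a nitrile.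

Compound 4, `COc1ccc(NS(=O)(=O)c2cc(Cl)cc(Cl)c2)cc1N1CCN(C)CC1`, has not yet been measured. It differs from compound 1 in one place: 3,5-dichlorophenyl in place of 3-cyanophenyl on a sulfonyl sulfur. The entering ring resembles the halogen-bearing rings of compound 2 and compound 3 more than the nitrile-bearing ring of compound 1, though it is smaller than either and carries neither bromine nor a second fused ring.

The step from compound 1 to compound 4 is therefore expected to go toward a lower number in this assay, clearly beyond the scatter: a 7.9-fold lower number from compound 1 to compound 4 (0.90 log units; beyond the scatter). Compound 4 is estimated to give 8 nM, with a likely range from 2 nM to 30 nM.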

Compound 4, inhibition constant: 2 nM
Beside the measured number, compound 4's estimate is 4.0-fold (0.60 log units) above it, and the stated range covers the measured number.
By their numbers in this assay, from the lowest: compound 3; then compounds 4 and 2 (each within the scatter of the next); then compound 1.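

In this assay, exchanging 3-cyanophenyl for 3,5-dichlorophenyl on the sulfonyl sulfur gives a 32-fold lower number from compound 1 to compound 4 (1.50 log units; beyond the scatter) while the count of heavy atoms in the group stays the same and the group remains a single six-membered aromatic ring, so the number responds strongly to what that ring carries and not only to how large it is. Compound 4 at 2 nM and compound 2 at 3.16 nM lie within the scatter of each other, which shows that a single ring bearing two chlorines, with no bromine or fluorine, can reach the same range in this assay. No measurement shown here explains the size of this step.

On these data alone, this single swap removes the nitrile and adds two chlorines at once, so the share of each remains open, and a plain phenyl ring or a phenyl ring with just one chlorine would be needed to separate them. Also open, as far as these compounds go, is how other groups on this ring, such as a methoxy group, an amine or a carboxylic acid, would compare with the two chlorines.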